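The source may hold more compounds than are shown below. What is called first, only, known or untested is meant among the compounds shown, and "the series" means these compounds.

Measured compounds:
- compound 1 `CCCCN1CCC(CNC(=O)c2cccc3c2OCCO3)CC1` gives 0.794 nM in an assay on isolated protein for inhibition of 5-hydroxytryptamine receptor 4 (Homo sapiens); a higher number here means a weaker inhibitor, a lower number a stronger inhibitor
- compound 2 `CS(=O)(=O)N1CCN(S(=O)(=O)CCCN2CCC(CNC(=O)c3cccc4c3OCCO4)CC2)CC1` gives 0.316 nM in this assay

Of the compounds shown here, two sharing the same core have been measured. Compound 2 stands at the lowest of the two numbers; its nearest neighbour is compound 1, whose value is higher by a margin that lies beyond the usual scatter. Among the measured compounds shown here, no pair of measured compounds differing in a single place is available, so there is no measured single-point step to draw on.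

Compound 3 `CC(C)S(=O)(=O)N1CCN(S(=O)(=O)CCCN2CCC(CNC(=O)c3cccc4c3OCCO4)CC2)CC1` is yet to be measured. It differs from compound 2 in one place: isopropyl in place of methyl on a sulfonyl sulfur. The change sits on a sulfonyl sulfur whose other neighbour is a sulfonamide nitrogen in a ring, far from the amide and the core; nothing in the measured data speaks to such an exchange. For compound 3 the step of a 1.1-fold higher number from compound 2 to compound 3 (0.04 log units; within the scatter) is expected to be small, most likely within the scatter, with no clear direction. Compound 3 is therefore expected to give about 0.35 nM in this assay, with a plausible range from 0.12 nM to 1 nM.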

Compound 3, inhibition constant: 0.126 nM
Compound 3: the middle estimate sits 2.8-fold (0.44 log units) above what was measured; the measured number falls inside the stated range.
By their numbers in this assay, from the lowest: compound 3; then compound 2; then compound 1.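

In this assay, among the compounds shown here, isopropyl in place of methyl on a sulfonyl sulfur gives a 2.5-fold lower number from compound 2 to compound 3 (0.40 log units; beyond the scatter), the first single-place step. The group at this place, on a sulfonyl sulfur whose other neighbour is a sulfonamide nitrogen in a ring, therefore registers in the read-out, and the larger of the two alkyl groups gives the lower number. This is a modest step from one pair, which fixes a direction for this exchange only and establishes no trend, and nothing measured here bears on the reason for it.

Open, on these data alone, is whether the number keeps falling as the group on the sulfonyl sulfur grows, or whether it turns back, as ethyl, tert-butyl, cyclopropyl or phenyl at this place would show. Also open, as far as these compounds go, is whether the sulfonyl link itself matters, which an acetyl or a plain methyl on the same ring nitrogen would test, and whether the step from methyl to isopropyl holds with a shorter or longer chain in the rest of the molecule.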